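The source may hold more compounds than are shown below. What is called first, only, known or untested is meant among the compounds shown, and "the series" means these compounds.

Three members of the series have numbers in a functional assay on MGC-803 cells (Homo sapiens) for antiproliferative activity, read by MTT assay, with a stated time of 72 h; a lower number here means a stronger inhibitor, a higher number a weaker inhibitor. Compound 1 `C#CCSc1nc(N/N=C/c2ccc(N(C)C)cc2)c2nnn(Cc3ccccc3)c2n1` gives 7620 nM. Compound 2 `CCCSc1nc(N/N=C(\C)c2ccccc2O)c2nnn(Cc3ccccc3)c2n1` gives 2310 nM. Compound 3 `CCCSc1nc(N/N=C(\C)c2ccccc2O)c2nnn(Cc3ccc(F)cc3)c2n1` gives 11000 nM, the highest number of the three; against compound 1 it lies within the scatter, against compound 2 beyond it. Going by the values given here, the only single-site step measured so far is a 4.8-fold higher number from compound 2 to compound 3 (0.68 log units; beyond the scatter), the entry of fluoro at the place where compound 4 now carries bromo. Compound 4 `CCCSc1nc(N/N=C(\C)c2ccccc2O)c2nnn(Cc3ccc(Br)cc3)c2n1` is not yet measured; its difference from compound 3 is bromo in place of fluoro on an aromatic carbon. Among the compounds with values here, no measured step exchanges one halogen for another at this place, so the direction of the change is open; the one halogen step known here concerns fluoro entering in place of hydrogen and says nothing about bromo in place of fluoro. With nothing to point either way, compound 4 is expected to stay near compound 3, and the expected step is a 1.2-fold lower number from compound 3 to compound 4 (0.09 log units; within the scatter), within the scatter. Compound 4 is therefore estimated at 9000 nM, in the range 3000 nM to 27000 nM.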

Compound 4, half-maximal inhibitory concentration: 11300 nM
The estimate for compound 4 lay 1.3-fold (0.10 log units) below the measured number; low and high end bracket the measured number.
By their numbers in this assay, from the lowest: compound 2; then compounds 1, 3 and 4 (each within the scatter of the next).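

In this assay, exchanging one halogen for the other on an aromatic carbon, para to a large group, gives a 1.0-fold higher number from compound 3 to compound 4 (0.01 log units; within the scatter), so 4-fluorobenzyl and 4-bromobenzyl cannot be told apart here. Bromo in place of hydrogen gives a 4.9-fold higher number from compound 2 to compound 4 (0.69 log units; beyond the scatter) and lies beyond the scatter, as the fluoro step does, so among compounds 2, 3 and 4 the higher number is not particular to fluoro. No measurement at hand explains the higher number with either halogen or the matching values of compound 3 and compound 4.

Going by these compounds, whether a group other than a halogen at this place, such as an amine or a methoxy group, also gives a higher number remains open. Also open, on these data alone, is whether either halogen has the same effect on compound 1, which differs at its other substituents.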